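The source may report more compounds than this note shows. Statements on the series, on what has been measured and on what is new or still open speak of the compounds shown alone.

Measured in a functional assay on C8166 cells (Homo sapiens) for cytotoxicity, read by MTT assay; on this read-out higher numbers stand for lower toxicity in this test and lower numbers for higher toxicity in this test:
- compound 1 `Cc1cc(S(N)(=O)=O)ccc1NC(=O)COc1ccc(Cl)cc1NC(=O)c1ccc(Cl)cc1Cl`: 61100 nM
- compound 2 `Cc1cc(S(N)(=O)=O)ccc1NC(=O)COc1ccc(Cl)cc1NC(=O)c1cc(Br)cc(Br)c1`: 89700 nM

For the measured compounds named here, compound 2 sits level with the only other measured compound, and the one measured step is a 1.5-fold higher number from compound 1 to compound 2 (0.17 log units; within the scatter). Going by the values given here, that step also exchanged the group on the carbonyl carbon, but no measured compound carries 2-phenylethenyl. Next is compound 3 `Cc1cc(S(N)(=O)=O)ccc1NC(=O)COc1ccc(Cl)cc1NC(=O)/C=C/c1ccccc1`, with the change (2-phenylethenyl in place of 3,5-dibromophenyl on a carbonyl carbon). In this assay no shift beyond the scatter is expected, and the estimated step is a 1.1-fold lower number from compound 2 to compound 3 (0.05 log units; within the scatter). The expected value for compound 3 is 80000 nM, with an estimated range of 35000 nM to 200000 nM.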

Compound 3, half-maximal cytotoxic concentration: 163000 nM
Compound 3: middle estimate off by 2.0-fold (0.31 log units), on the low side; low and high end bracket the measured number.
By their numbers in this assay, from the lowest: compounds 1, 2 and 3 (each within the scatter of the next, the first and the last beyond it).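

In this assay, changing the group on this carbonyl carbon now gives a step beyond the scatter, though a modest one, when 2-phenylethenyl replaces 2,4-dichlorophenyl (a 2.7-fold higher number from compound 1 to compound 3 (0.43 log units; beyond the scatter)). Replacing 3,5-dibromophenyl with 2-phenylethenyl stays within the scatter (a 1.8-fold higher number from compound 2 to compound 3 (0.26 log units; within the scatter)), so the effect of 2-phenylethenyl depends on the group used for comparison. Nothing available explains this difference.

Open, as far as these compounds go, is whether 2-phenylethyl, with the double bond saturated, would keep the number of compound 3 in this assay. From the compounds shown here alone, an amine or a carboxylic acid at this position also remains untested within these compounds.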